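Chloro for bromo: one halogen exchanged at the far ring

The compounds below may be only part of what the source reports. "The series", "measured", "known", "first", "only" and "open" are said of these compounds alone.

Measured so far:
compound 1 `COc1cc(OC)c(OC)cc1/C=C/COC(=O)/C=C/c1ccc(Br)cc1` gives 100%
compound 2 `COc1cc(OC)c(OC)cc1/C=C/COC(=O)/C=C/c1cc(OC)c(OC)c(OC)c1` gives 100%

Two esters sharing the same core have been tested in a functional assay on the whole organism (strain Kunming) with Mus musculus as the target, with a stated time of 0.5 h, at a dose of 300 mg/kg by the intraperitoneal route; on this read-out lower numbers stand for a stronger effect and higher numbers for a weaker effect at the one dose given. Compound 1 carries a 4-bromophenyl group at one end of its chain, and in this assay compound 1 gives 100%. Compound 2 instead carries a trimethoxyphenyl group at that position, and in this assay compound 2 gives 100%. On the digits shown, compound 1 stands level with compound 2; the two values lie within the usual scatter of each other, so no order between them can be claimed.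

The next compound, compound 3 `COc1cc(OC)c(OC)cc1/C=C/COC(=O)/C=C/c1ccc(Cl)cc1`, differs from compound 1 in a single place: chloro in place of bromo on an aromatic carbon. Within the data shown here, no step between measured compounds is available to guide this change, so the expectation rests on the two values alone. Since compound 1 and compound 2 both sit at the same level despite a much larger difference at that ring, the step of a number 3 percentage points lower from compound 1 to compound 3 (within the scatter) is expected to be none beyond the scatter. Compound 3 is therefore estimated to give 97%, with a likely range from 80% to 100%.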

Compound 3, a percentage reported as activity, at one dose (the size of the read-out at that dose, not a potency): 100%
Beside the measured number, compound 3's estimate is 3 percentage points below it; measured number inside the range.
By their numbers in this assay, from the lowest: compounds 1, 2 and 3 (each within the scatter of the next).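

Swapping one halogen on the far ring is the first one-place comparison at this position, and in this assay it shows no change at the digits printed from compound 1 to compound 3 (within the scatter) for the change from 4-bromophenyl to 4-chlorophenyl. At this one dose, then, bromo and chloro on this aromatic carbon cannot be told apart, although a single dose gives the size of the read-out rather than a potency, so any difference at other doses stays out of view. Nothing available here explains why these two halogens give the same reading.

On these data alone, what remains open is whether a group of a different kind on this ring, such as an amine, a hydroxyl or a carboxylic acid, would bring the number down from this level, and whether fluoro or plain hydrogen at the same place would match bromo and chloro. The compounds shown also all keep the ester and the shared core, so it is equally open whether an amide in place of the ester, or a longer chain between the two rings, would move the read-out.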